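The source may hold more compounds than are shown below. What is called first, only, known or untested is meant among the compounds shown, and "the series" means these compounds.

Measured in an ADME assay on L6 cells (Rattus norvegicus) for cytotoxicity, read by resazurin assay, with a stated time of 72 h; on this read-out lower numbers stand for stronger inhibition and higher numbers for weaker inhibition:
- compound 1 `COCC(=O)Nc1c(C(=O)OC)n(CCC(C)C)c2ncc(NC(C)CCC=C(C)C)cc12`: 63000 nM
- compound 2 `COCC(=O)Nc1c(C(=O)OC)n(CCC(C)C)c2ncc(NC3CCCCCCC3)cc12`: 56000 nM

Compound 2 at 56000 nM and compound 1 lie within the scatter of each other, so neither stands apart on these numbers.

Compound 3 `COCC(=O)Nc1c(C(=O)OC)n(CCC(C)C)c2ncc(NC(C)C)cc12` carries isopropyl in place of cyclooctyl on a nitrogen on an aromatic ring. One measured step changes the group at this place: a 1.1-fold lower number from compound 1 to compound 2 (0.05 log units; within the scatter), which stays within the scatter. That single step is thin evidence, and neither measured compound carries a group as short as isopropyl. Little movement is therefore expected in this assay, with at most a slight lean towards a higher number. The estimated change is a 1.3-fold higher number from compound 2 to compound 3 (0.13 log units; within the scatter), with no step beyond the scatter expected. Compound 3 is estimated at 75000 nM, with an expected range of 38000 nM to 150000 nM.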

Compound 3, half-maximal inhibitory concentration: 56000 nM
The estimate for compound 3 lay 1.3-fold (0.13 log units) above the measured number; the range from low to high includes it.
By their numbers in this assay, from the lowest: compounds 2, 3 and 1 (each within the scatter of the next).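

In this assay, replacing cyclooctyl with isopropyl on the nitrogen on the aromatic ring gives no change at the digits printed from compound 2 to compound 3 (within the scatter). The comparison with the open-chain group gives a 1.1-fold lower number from compound 1 to compound 3 (0.05 log units; within the scatter). Across these three compounds, neither the eight-membered ring nor the 1,5-dimethylhex-4-en-1-yl chain is needed for a number at this level, and a group of 3 heavy atoms with no ring sits within the scatter of both; no measurement on hand offers an explanation for this flat result.

Going by these compounds, all three groups at this position are hydrocarbons, so it remains open whether a chain ending in a primary amine or a carboxylic acid, or a phenyl ring, would move the number. On these data alone, the groups elsewhere on the shared core are identical in all three compounds, so their part in this read-out also remains open.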